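The source may hold more compounds than are shown below. What is called first, only, known or untested is meant among the compounds shown, and "the series" means these compounds.

Of the compounds shown here, three have been tested in a functional assay on NCI-H460 cells (Homo sapiens) for cytotoxicity, read by MTT assay, with a stated time of 68 h (a lower number here means a stronger inhibitor, a higher number a weaker inhibitor), so far. Compound 1 `O=C(Nc1cccc(-c2cccc(NC(=O)C(Cl)Cl)c2)c1)C(Cl)Cl` is the starting point. In this assay compound 1 gives > 50000 nM, which is a limit of the assay rather than a number. Compound 2 `CSc1cccc(-c2cc(NC(=O)C(Cl)Cl)cc(-c3cccc(SC)c3)c2)c1` likewise returns only > 30000 nM in this assay, again a limit and not a number. Going by the values given here, compound 3 `O=C(Nc1cccc(-c2ccoc2)c1)C(Cl)Cl` is the one compound with a measured number, giving 37600 nM in this assay. Compound 1 therefore stands at the far weak end of what is shown: of the three values, it sits at the limit of > 50000 nM in this assay, at which 1 of the 3 values shown sits, one other sits at the limit of > 30000 nM in this assay, at which 1 of the 3 values shown sits, and compound 3 alone yields a number.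

Compound 4 `Nc1cccc(-c2cccc(NC(=O)C(Cl)Cl)c2)c1` has not yet been measured. It differs from compound 1 in one place: hydrogen in place of (dichloromethyl)carbonyl on a nitrogen on an aromatic ring. Among the compounds with values here, no measured pair shows what such a change does here, so no size can be read off directly. Compound 1 already sits at a limit, and compound 3, which also carries a single (dichloromethyl)carbonyl group, is weak. The expectation is therefore a step of an at least 1.2-fold lower number from compound 1 to compound 4 (0.09 log units; that floor lies within the scatter), no larger than the scatter, with compound 4 expected to remain weak. Compound 4 is estimated at 40000 nM, between 12000 nM and 130000 nM.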

Compound 4, half-maximal inhibitory concentration: > 50000 nM
Compound 4 was reported as a limit; the forecaster's own chance of this, stated with the estimate: 55%; middle value at least 1.2-fold (0.09 log units) from the limit.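

Compound 1 and compound 4 both return only a limit of the assay rather than a number, so no step can be read between them. The compounds shown leave open whether replacing (dichloromethyl)carbonyl with hydrogen on that nitrogen changes the result in this assay at all, and if so, in which direction and by how much.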